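This account rests on a few compounds, and the source may have more. Where it says the series, first, only, none or still open, it means among the compounds named here.

Three compounds with one shared core were tested in a functional assay on MCF7 cells (Homo sapiens) for inhibition, read by colorimetric assay and MTT assay, with a stated time of 72 h; on this read-out higher numbers stand for weaker inhibition and lower numbers for stronger inhibition. Compound 1 `C=CCCCCOc1ccccc1-c1cnc(OCCCC=C)n1C` gives 7000 nM, compound 2 `C=CCCCCCOc1ncc(-c2ccccc2OCCCCC=C)n1C` gives 63000 nM, and compound 3 `C=CCCCCOc1ccccc1-c1cnc(S(=O)(=O)c2ccccc2)n1C` gives 25000 nM. The change from compound 2 to compound 1, (vinyl in place of but-3-en-1-yl on a saturated chain carbon, three bonds along the chain from an oxygen on an aromatic ring), brought a 9.0-fold lower number from compound 2 to compound 1 (0.95 log units; beyond the scatter). Compound 3 carries a different core, described by phenylsulfonyl in place of (hept-6-en-1-yl)oxy on an aromatic carbon, and shows a 2.5-fold lower number from compound 2 to compound 3 (0.40 log units; beyond the scatter) and a 3.6-fold higher number from compound 1 to compound 3 (0.55 log units; beyond the scatter). Compound 4 `C=CCCOc1ccccc1-c1cnc(S(=O)(=O)c2ccccc2)n1C` is not yet measured; it differs from compound 3 by vinyl in place of but-3-en-1-yl on a saturated chain carbon, two bonds along the chain from an oxygen on an aromatic ring. This is the same kind of change as that from compound 2 to compound 1, though here the saturated chain carbon sits two bonds, not three, along the chain from the oxygen on the aromatic ring. Because the earlier shortening gave a 9.0-fold lower number from compound 2 to compound 1 (0.95 log units; beyond the scatter), the step from compound 3 to compound 4 in this assay is expected to be a 2.1-fold lower number from compound 3 to compound 4 (0.32 log units; beyond the scatter), smaller since the change occurs on a different core and at a different place. Compound 4 is therefore estimated at 12000 nM, between 4000 nM and 35000 nM.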

Compound 4, half-maximal inhibitory concentration: 67000 nM
Beside the measured number, compound 4's estimate is 5.6-fold (0.75 log units) below it, outside the stated range (above it).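

Replacing but-3-en-1-yl with vinyl, two bonds along the chain from an oxygen on an aromatic ring, gave a 2.7-fold higher number from compound 3 to compound 4 (0.43 log units; beyond the scatter) in this assay. The same kind of change therefore ran in opposite directions in the two pairs, so it did not carry from one core to the other in this series: the same change on two cores in this assay, a 9.0-fold lower number (0.95 log units; beyond the scatter) from compound 2 to compound 1 and a 2.7-fold higher number (0.43 log units; beyond the scatter) from compound 3 to compound 4, 24-fold (1.38 log units) apart, beyond the scatter of two such steps. The two pairs differ in both core and the place of the change, so they do not show which of these separates the outcomes, nor how the change would behave on any other core.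

The compounds shown leave open whether the reversal would persist if an amine or a carboxylic acid replaced the phenylsulfonyl group. They also leave open how a longer chain would read out at this place on the core of compound 3.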